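This account rests on a few compounds, and the source may have more. Where it says the series, first, only, none or still open, it means among the compounds named here.

Measured so far in a functional assay on MCF7 cells (Homo sapiens) for antiproliferative activity, read by MTT assay, with a stated time of 72 h; a higher number here means a weaker inhibitor, a lower number a stronger inhibitor
compound 1 `COc1ccc(/C=C2/CN(C)/C(=N/c3ccc(C)cc3)S2)cc1` gives 7600 nM
compound 2 `COc1ccc(/C=C2/CN(C)/C(=N/c3ccc(C(F)(F)F)cc3)S2)cc1` gives 24100 nM
compound 3 `COc1ccc(/C=C2\S/C(=N\c3ccc(F)cc3)N(C)C2=O)cc1` gives 66500 nM

Compound 2 at 24100 nM holds the middle place among the three numbers. Compound 1 stands lower and compound 3 higher, both beyond the scatter.

Going by the values given here, compound 4 `COc1ccc(/C=C2/CN(C)/C(=N/c3ccc([N+](=O)[O-])cc3)S2)cc1` has no measurement yet. Its change from compound 2 is nitro in place of trifluoromethyl on an aromatic carbon and amounts to nitro in place of trifluoromethyl on an aromatic carbon, para to a large group.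

Among the compounds with values here, only one measured step bears on this position: a 3.2-fold higher number from compound 1 to compound 2 (0.50 log units; beyond the scatter) with trifluoromethyl in place of methyl on an aromatic carbon. That step is modest but beyond the scatter. Within the data shown here, compound 3 differs from compound 2 in more than one place and supplies no comparable step. Among the measured compounds shown here, no measured compound carries nitro, so the data give no firm direction. For the measured compounds named here, the single step serves only as a guide to size, and a smaller change is expected in this assay with a slight lean towards a lower number.

The estimated step is a 1.2-fold lower number from compound 2 to compound 4 (0.08 log units; within the scatter) and is expected to stay within the scatter.

For compound 4 the estimate is 20000 nM with an expected range from 7000 nM to 55000 nM in this series.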

Compound 4, half-maximal inhibitory concentration: 9800 nM
For compound 4 the middle estimate is 2.0-fold (0.31 log units) above the measured one; low and high end bracket the measured number.
By their numbers in this assay, from the lowest: compounds 1 and 4 (each within the scatter of the next); then compound 2; then compound 3.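

In this assay, the place on the aromatic ring para to a large group now shows a second exchange that moves the number beyond the scatter: a 2.5-fold lower number from compound 2 to compound 4 (0.39 log units; beyond the scatter). This shows that the response at this position is not confined to the exchange of methyl for trifluoromethyl, and that nitro and trifluoromethyl are not interchangeable here. Nitro and methyl, by contrast, cannot be told apart in this assay, with a 1.3-fold higher number from compound 1 to compound 4 (0.11 log units; within the scatter), so among the three compounds that differ only at this place, compound 2 alone stands apart from the other two. No measurement at hand speaks to the reason for this difference.

Three groups at one place cannot show whether compound 2 is a lone exception or one end of a wider trend, and an amine, a carboxylic acid or a longer alkyl chain at the same place would test this. As far as these compounds go, it also remains open whether these steps carry over to the core of compound 3, which differs from the others in more than one place.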